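Cytotoxicity notes: aryl swap on the oxalamide series

This account rests on a few compounds, and the source may have more. Where it says the series, first, only, none or still open, it means among the compounds named here.

The series shares the core of compound 1 `Cc1nc(C(NC(=O)C(=O)Nc2ccc(F)c(F)c2)C2CCCCN2)sc1CO` and is followed in an ADME assay on TZM-b1 cells (Homo sapiens) for cytotoxicity, read by XTT assay, with a stated time of 3 days; on this read-out higher numbers stand for lower toxicity in this test and lower numbers for higher toxicity in this test. For compound 1 the reading is a limit, > 87000 nM. Compound 2 `CC(=O)N1CCCCC1C(NC(=O)C(=O)Nc1ccc(Cl)cc1)c1nc(C)c(CCO)s1` likewise returns a limit, > 84000 nM. Compound 3 `Cc1nc(C(NC(=O)C(=O)Nc2ccc(Cl)cc2)C2CCCNC2)sc1CCO` gives 59400 nM. Among the measured compounds shown here, the one measured step, an at least 1.4-fold lower number from compound 2 to compound 3 (0.15 log units; that floor lies within the scatter), is a floor and establishes no change. Compound 4 `CC(=O)c1ccc(NC(=O)C(=O)NC(c2nc(C)c(CO)s2)C2CCCCN2)cc1` differs from compound 1 by 4-acetylphenyl in place of 3,4-difluorophenyl on an amide-type nitrogen. For the measured compounds named here, no measured step covers this aryl change, and the single step available, an at least 1.4-fold lower number from compound 2 to compound 3 (0.15 log units; that floor lies within the scatter), gives no direction, so no movement beyond the scatter is anticipated. For compound 4 the expected step is a step that the limit leaves unreadable from compound 1 to compound 4, within the scatter. Compound 4 is estimated at 90000 nM, with a range of 40000 nM to 200000 nM.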

Compound 4, half-maximal cytotoxic concentration: > 86000 nM
Compound 4: a limit, no number; the forecaster's own chance of this, stated with the estimate: 65%; the middle value lies beyond the limit too.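

In this assay compound 1 and compound 4 both return limits, and no step can be read between them. The compounds shown leave open whether 4-acetylphenyl in place of 3,4-difluorophenyl changes this read-out at all.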